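The source may report more compounds than this note shows. Statements on the series, on what has been measured and on what is new or still open speak of the compounds shown alone.

Of the compounds shown here, three of one shared core have been tested in a functional assay on the whole organism (strain Swiss) with Mus musculus as the target, in the maximal electroshock model, with a stated time of 1 h, at a dose of 300 mg/kg by the intraperitoneal route; a lower number here means a weaker effect, a higher number a stronger effect of the compound at the dose given. Compound 2, `COCC(C(=O)N1CCN(c2cccc(C(F)(F)F)c2)CC1)N1C(=O)CCC1=O`, gives 100% and stands highest of the three; compound 1, `CCC(C(=O)N1CCN(c2ccccc2F)CC1)N1C(=O)CCC1=O`, gives 50%, and compound 3, `CCC(C(=O)N1CCN(c2ccccc2C(F)(F)F)CC1)N1C(=O)CCC1=O`, gives 0%. For the measured compounds named here, the one measured step, a number 50 percentage points lower from compound 1 to compound 3 (beyond the scatter), concerns the group on the aromatic ring, with trifluoromethyl in place of fluoro.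

Compound 4, `CC(C(=O)N1CCN(c2cccc(C(F)(F)F)c2)CC1)N1C(=O)CCC1=O`, is not yet measured. It differs from compound 2 by hydrogen in place of methoxy on a saturated chain carbon, two bonds along the chain from an amide-type nitrogen in a ring and a carbonyl carbon. Going by the values given here, no measured pair touches that part of the molecule, so the single known step offers no direct guide. Compound 2 sits at the top of the range this assay can report, so the number can only stay or fall. The expectation is therefore a moderate fall, a number 25 percentage points lower from compound 2 to compound 4 (beyond the scatter), with wide uncertainty. Compound 4 is expected to give about 75% in this assay, within 25% to 100%.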

Compound 4, a percentage reported as activity, at one dose (the size of the read-out at that dose, not a potency): 100%
The estimate for compound 4 lay 25 percentage points below the measured number, within the range that was stated.
By their numbers in this assay, from the lowest: compound 3; then compound 1; then compounds 2 and 4 (each within the scatter of the next).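

In this assay, for the compounds shown here, there is no change at the digits printed from compound 2 to compound 4 (within the scatter), the first measured change at this position, so the methoxy group is not needed for the full read-out at this dose. Both compounds sit at the top of the range this read-out can report, which means that a real difference in strength between them could stay hidden here. No measurement is available to explain why the read-out holds when methoxy is removed.

Still open, on these data alone, is whether a longer chain, an amine or a carboxylic acid on this saturated chain carbon would hold the read-out as well. Also open, as far as these compounds go, is how compound 2 and compound 4 would compare at a lower dose, where the read-out might have room to separate them.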